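Pentafluorosulfanyl in place of the bicyclic group on the benzamide

The source may report more compounds than this note shows. Statements on the series, on what has been measured and on what is new or still open speak of the compounds shown alone.

Measured compounds in an ADME assay on microsomes from liver (Rattus norvegicus, strain Sprague-Dawley) for metabolic stability, read by HPLC, using NADPH, with stated times of 5 min and 60 min, tested at 10 uM; a higher number here means that the compound lasts longer, a lower number that the compound disappears faster:
compound 1, `CS(=O)(=O)Nc1ccc(CNC(=O)c2ccc(C34CC(C3)C4)cc2)c(Cl)c1`: 1.35 h
compound 2, `CS(=O)(=O)Nc1ccc(CNC(=O)c2ccc(N3CCCCC3)cc2)c(Cl)c1`: 1.12 h
compound 3, `CS(=O)(=O)Nc1ccc(CNC(=O)c2ccc(CC(F)(F)F)cc2)c(Cl)c1`: 1.03 h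

The three numbers sit close together. From compound 1 the steps are a 1.2-fold lower number from compound 1 to compound 2 (0.08 log units; within the scatter) and a 1.3-fold lower number from compound 1 to compound 3 (0.12 log units; within the scatter), and between the other two a 1.1-fold lower number from compound 2 to compound 3 (0.04 log units; within the scatter); none of these exceeds the scatter, so compound 1 cannot be set apart from compounds 2 and 3 on the half-life.

Compound 4, `CS(=O)(=O)Nc1ccc(CNC(=O)c2ccc(S(F)(F)(F)(F)F)cc2)c(Cl)c1`, is not yet measured. Its change from compound 1 is a group of 6 heavy atoms (5 fluorine, 1 sulfur; no ring) in place of a group of 5 heavy atoms (5 carbon; 2 four-membered non-aromatic rings of carbon only), on an aromatic carbon.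

Among the compounds with values here, the steps that bear on it are those that replace the same bicyclic group on compound 1: a 1.2-fold lower number from compound 1 to compound 2 (0.08 log units; within the scatter) and a 1.3-fold lower number from compound 1 to compound 3 (0.12 log units; within the scatter). Both stayed within the scatter, whether a ring or a fluorinated chain entered at that carbon. Nothing in the three compounds points to a step beyond the scatter for a fluorinated, ring-free group entering at the same place, so no change beyond the scatter is expected in this assay.

Compound 4 is therefore expected to give about 1.3 h, in the range 0.7 h to 2.5 h. The step this estimate means is a 1.0-fold lower number from compound 1 to compound 4 (0.02 log units; within the scatter), expected to stay within the scatter.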

Compound 4, half-life: 2.3 h
Beside the measured number, compound 4's estimate is 1.8-fold (0.25 log units) below it; measured number inside the range.
By their numbers in this assay, from the lowest: compounds 3, 2, 1 and 4 (each within the scatter of the next, the first and the last beyond it).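

In this assay this position, an aromatic carbon para to a large group, now gives steps beyond the scatter: pentafluorosulfanyl produces a 2.2-fold higher number from compound 3 to compound 4 (0.35 log units; beyond the scatter) and a 2.1-fold higher number from compound 2 to compound 4 (0.31 log units; beyond the scatter), both modest, where the earlier replacements could not be told apart. Against the bicyclic group the same change gives a 1.7-fold higher number from compound 1 to compound 4 (0.23 log units; within the scatter), so the two groups cannot be separated on half-life, and the position has yet to show a clear gain over compound 1. No measurement available here accounts for these steps.

On these data alone, how an amine, a carboxylic acid or a longer fluorinated chain at this carbon would stand against compound 4 in this assay remains open. Within the data shown here, also open is whether the steps to pentafluorosulfanyl carry over to a core other than the one shared by these compounds.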